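Aromatic acyl group on a saturated core: compound 3 expected

This account rests on a few compounds, and the source may have more. Where it says the series, first, only, none or still open, it means among the compounds named here.

Measured compounds:
- compound 1 `CC(C)OC(=O)C1=CN(C(=O)c2cccs2)CC(C)(C)c2cc(C#N)[nH]c21`: 16 nM
- compound 2 `CC(C)OC(=O)C1CN(C(=O)C2CCCCC2)CC(C)(C)c2cc(C#N)[nH]c21`: 1900 nM

In an assay on HEK293 cells for agonist activity at Bile acid receptor (Homo sapiens), read by a luciferase reporter (on this read-out lower numbers stand for an effect already at smaller amounts and higher numbers for an effect only at larger amounts of compound), compound 1 gives 16 nM, while compound 2 gives 1900 nM. Compound 2 thus stands highest of the two numbers, and its gap to compound 1 lies beyond the scatter. The two compounds differ in more than one place, so no single change can be read from this pair.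

Compound 3 `CC(C)OC(=O)C1CN(C(=O)c2ccc(F)cc2)CC(C)(C)c2cc(C#N)[nH]c21` keeps the saturated core of compound 2 and changes only the acyl group: 4-fluorophenyl in place of cyclohexyl on a carbonyl carbon. Within the data shown here, no measured pair isolates this change. Because compound 1, which also carries an aromatic acyl group, gives 16 nM, compound 3 is expected to land below compound 2 but not as low as compound 1. The expected step is a 6.3-fold lower number from compound 2 to compound 3 (0.80 log units; beyond the scatter). Compound 3 is estimated at 300 nM, within 60 nM to 1500 nM.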

Compound 3, half-maximal effective concentration: 640 nM
The estimate for compound 3 lay 2.1-fold (0.33 log units) below the measured number; measured number inside the range.
By their numbers in this assay, from the lowest: compound 1; then compound 3; then compound 2.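

Among these compounds, this is the first comparison in which only the acyl group changes on the saturated core. In this assay, 4-fluorophenyl in place of cyclohexyl on a carbonyl carbon gives a 3.0-fold lower number from compound 2 to compound 3 (0.47 log units; beyond the scatter) and shows that the group on this carbonyl carbon does shift the number on this core, with the aromatic ring giving the lower one. Nothing at hand explains the direction or the size of this step.

Compound 1 differs from compound 3 in more than one place, which leaves open how much of the gap between them belongs to the acyl group and how much to the core. Going by these compounds, it also remains open whether the fluorine contributes at all, a question that plain phenyl on the same carbonyl carbon would address.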